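The source may hold more compounds than are shown below. What is called first, only, known or untested is meant among the compounds shown, and "the series" means these compounds.

In a functional assay on HCT-116 cells (Homo sapiens) for antiproliferative activity, read by MTT assay, with a stated time of 24 h (on this read-out higher numbers stand for weaker inhibition and lower numbers for stronger inhibition), compound 1 `C=CCOc1ccc2c(=O)c(-c3cc(OC)c(OC)cc3OC)coc2c1` gives 6600 nM, compound 2 `COc1cc(OC)c(-c2coc3cc(OCc4ccccc4C)ccc3c2=O)cc1OC` gives 2900 nM and compound 3 `COc1cc(OC)c(-c2coc3cc(OCc4ccc(C#N)cc4)ccc3c2=O)cc1OC` gives 4220 nM. Compound 3 lies within the scatter of both other compounds. Compound 4 `COc1cc(OC)c(-c2coc3cc(OCc4ccc(Cl)cc4)ccc3c2=O)cc1OC` differs from it by chloro in place of cyano on an aromatic carbon, with chloro in place of cyano on an aromatic carbon. For the measured compounds named here, no measured step makes this exact exchange. The closest evidence is a 1.5-fold higher number from compound 2 to compound 3 (0.16 log units; within the scatter), a change of aryl group, alongside a 1.6-fold lower number from compound 1 to compound 3 (0.19 log units; within the scatter). The largest step in the set is only modest: a 2.3-fold lower number from compound 1 to compound 2 (0.36 log units; beyond the scatter). No shift beyond the scatter is therefore expected in this assay. The expected change is a 1.2-fold lower number from compound 3 to compound 4 (0.07 log units; within the scatter). Compound 4 is estimated at 3600 nM, with an expected range of 1900 nM to 6800 nM.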

Compound 4, half-maximal inhibitory concentration: 4450 nM
For compound 4 the middle estimate is 1.2-fold (0.09 log units) below the measured one, and the stated range covers the measured number.
By their numbers in this assay, from the lowest: compounds 2, 3, 4 and 1 (each within the scatter of the next, the first and the last beyond it).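

Chloro and cyano at this aromatic carbon, para to a large group, can now be compared directly, and the exchange stays within the scatter in this assay (a 1.1-fold higher number from compound 3 to compound 4 (0.02 log units; within the scatter)). The 4-chlorobenzyl group also stays within the scatter of the two other groups on the oxygen (a 1.5-fold higher number from compound 2 to compound 4 (0.19 log units; within the scatter); a 1.5-fold lower number from compound 1 to compound 4 (0.17 log units; within the scatter)). Nothing available on these compounds accounts for the flat result.

Still open, from the compounds shown here alone, is whether an amine or a carboxylic acid at this carbon would give a step beyond the scatter. A longer chain between the oxygen and the aromatic ring also remains untested in the compounds shown.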